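The compounds below may be only part of what the source reports. "The series", "measured", "known", "first", "only" and "open" are said of these compounds alone.

The three measured compounds share one core, a benzamide carrying a fluoro and a nitrile, and differ only in the aromatic amine that forms the amide. Compound 1 (`Cc1cccnc1NC(=O)c1cc(F)cc(C#N)c1`) bears a methylpyridine, compound 3 (`Cc1ccccc1NC(=O)c1cc(F)cc(C#N)c1`) a methylphenyl, and compound 2 (`N#Cc1cc(F)cc(C(=O)Nc2cccc(Cl)c2)c1`) a chlorophenyl. All three were tested in an in vitro functional assay on HEK293-A cells for antagonist activity at metabotropic glutamate receptor 5 (Rattus norvegicus), read by calcium flux; on this read-out higher numbers stand for weaker inhibition and lower numbers for stronger inhibition. In this assay compound 1 gives > 30000 nM, which is a limit of the assay and not a number. In this assay compound 3 likewise gives > 30000 nM, again only a limit. In this assay, within the data shown here, compound 2 gives 45 nM, the only real number among the three, the other two sitting at the limit of > 30000 nM in this assay, at which 2 of the 3 values shown sit.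

Compound 4 (`CCc1cccc(NC(=O)c2cc(F)cc(C#N)c2)c1`) has not yet been measured. It keeps the chlorophenyl arrangement of compound 2 but with ethyl in place of chloro on an aromatic carbon. Among the measured compounds shown here, no pair of measured compounds differs in one place, so the size of this step cannot be read from the measured data; a modest move toward weaker inhibition, perhaps a little beyond the scatter, is what I expect. In this assay compound 4 is therefore expected to give about 120 nM, within a range from 30 nM to 500 nM. This estimate means an expected step from a 2.7-fold higher number from compound 2 to compound 4 (0.43 log units; beyond the scatter).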

Compound 4, half-maximal inhibitory concentration: 4940 nM
Compound 4: middle estimate off by 41-fold (1.61 log units), on the low side; measured number above the stated range.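

In this assay, this position proves highly sensitive: putting ethyl in place of chloro on an aromatic carbon, meta to a large group, gives a 110-fold higher number from compound 2 to compound 4 (2.04 log units; beyond the scatter). Among these compounds, this is the first step that can be read, and it shows that a small edit can cost a great deal of inhibition, since only 1 heavy atom leaves, 2 heavy atoms enter, and neither group carries a ring, a charge, a hydrogen-bond donor or a hydrogen-bond acceptor. Compound 4 still gives a real number and not a limit, so the change weakens inhibition strongly without reaching the ceiling of the read-out: the limit of > 30000 nM in this assay, at which 2 of the 4 values shown sit.

With a single comparable pair, the data cannot say why the step is so large, or whether it comes from the extra carbon or from the loss of chloro itself. Groups such as bromo, methoxy or an amine at this same position would show whether chloro is a rare fit here or one of several groups that are tolerated.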